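This account rests on a few compounds, and the source may have more. Where it says the series, first, only, none or still open, it means among the compounds named here.

Measured in a functional assay on HeLa cells (Homo sapiens) for cytotoxicity, read by sulforhodamine B assay; on this read-out lower numbers stand for stronger inhibition and higher numbers for weaker inhibition:
compound 1 `CCOC(=O)c1ccc(S(=O)(=O)NC(C2=CC(=O)c3c(O)ccc(O)c3C2=O)C(C)C)cc1` gives 850 nM
compound 2 `Cc1ccc(S(=O)(=O)NC(C)C2=CC(=O)c3c(O)ccc(O)c3C2=O)cc1` gives 5340 nM

Compound 2 holds the higher of the two numbers, and the gap down to compound 1 lies beyond the scatter. Compound 3 `CC(NS(=O)(=O)c1cccc(Br)c1)C1=CC(=O)c2c(O)ccc(O)c2C1=O` is not yet measured. It carries 3-bromophenyl in place of 4-methylphenyl on a sulfonyl sulfur. For the measured compounds named here, no measured pair shows this change, so the expectation is weakly founded. The estimated 1.4-fold lower number from compound 2 to compound 3 (0.15 log units; within the scatter) in this assay is expected to stay within the scatter. The expected value for compound 3 is 3800 nM (estimated range 1300 nM to 10000 nM).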

Compound 3, half-maximal inhibitory concentration: 6350 nM
For compound 3 the middle estimate is 1.7-fold (0.22 log units) below the measured one; the range from low to high includes it.
By their numbers in this assay, from the lowest: compound 1; then compounds 2 and 3 (each within the scatter of the next).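

In this assay, the first pair differing in one place gives a 1.2-fold higher number from compound 2 to compound 3 (0.08 log units; within the scatter) when 3-bromophenyl replaces 4-methylphenyl on a sulfonyl sulfur. At this position, the two groups therefore cannot be told apart on this read-out. Nothing measured bears on why.

On these data alone, compound 1 differs from compound 2 in more than one place, so the source of their gap remains open. Also open, as far as these compounds go, is how a carboxylic acid or an amine on the phenyl ring would read in this assay here.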